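A few compounds are considered here, and "the series" means these few. Any claim that something is new, unique, unknown or untested is made for them only; others in the source may bear on it.

Compound 1, `O[C@H]1Cc2ccccc2C1NC1CCN(CCCc2c[nH]c3ccc(-n4cnnc4)cc23)CC1`, in an assay on CHO cells for displacement of a labelled ligand from 5-hydroxytryptamine receptor 1B (Homo sapiens) (on this read-out lower numbers stand for stronger inhibition and higher numbers for weaker inhibition), gives 300 nM.
Compound 2, `CC(C)=CCCN(C)C1CCN(CCCc2c[nH]c3ccc(-n4cnnc4)cc23)CC1`, in this assay gives 24 nM.
Compound 3, `O[C@@H]1Cc2ccccc2[C@H]1NC1CCN(CCCc2c[nH]c3ccc(-n4cnnc4)cc23)CC1`, in this assay gives 210 nM.

Compound 3 stands second highest of the three numbers in this assay. Its nearest neighbour is compound 1, with a 1.4-fold lower number from compound 1 to compound 3 (0.15 log units; within the scatter); the two share the same atoms and bonds and differ only in how the stereocentres are drawn (the fact that one of compounds 1 and 3 is drawn with a defined configuration and the other without, at the place where they differ). Its furthest neighbour is compound 2, with an 8.8-fold higher number from compound 2 to compound 3 (0.94 log units; beyond the scatter).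

Compound 4, `CN(Cc1ccco1)C1CCN(CCCc2c[nH]c3ccc(-n4cnnc4)cc23)CC1`, is obtained from compound 3 by the change (((furan-2-yl)methyl)(methyl)amino in place of (2-hydroxy-2,3-dihydro-1H-inden-1-yl)amino on a saturated ring carbon). Among the compounds with values here, two measured steps bear on this. Replacing the indanylamino group of compound 1 with a tertiary methyl(alkenyl)amino group gave a 13-fold lower number from compound 1 to compound 2 (1.10 log units; beyond the scatter), and the reverse exchange on compound 3 gave an 8.8-fold higher number from compound 2 to compound 3 (0.94 log units; beyond the scatter). From the compounds shown here alone, compound 4 likewise carries a tertiary amine with a methyl and a small carbon substituent on that ring carbon, so a lower number in this assay than compound 3 is expected, of a size comparable to those two steps, though the furanylmethyl group is untested here and the step could be smaller.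

For compound 4 the estimate in this assay is therefore 40 nM, with a range from 12 nM to 150 nM, which would mean an expected step of a 5.3-fold lower number from compound 3 to compound 4 (0.72 log units; beyond the scatter).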

Compound 4, half-maximal inhibitory concentration: 89 nM
Compound 4: middle estimate off by 2.2-fold (0.35 log units), on the low side; measured number inside the range.
By their numbers in this assay, from the lowest: compound 2; then compound 4; then compounds 3 and 1 (each within the scatter of the next).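

With a 2.4-fold lower number from compound 3 to compound 4 (0.37 log units; beyond the scatter) and a 3.4-fold lower number from compound 1 to compound 4 (0.53 log units; beyond the scatter) in this assay, the ((furan-2-yl)methyl)(methyl)amino group joins the methyl(4-methylpent-3-en-1-yl)amino group of compound 2 in lowering the number relative to the (2-hydroxy-2,3-dihydro-1H-inden-1-yl)amino group, so the earlier drop is not tied to that one alkenyl chain. Within the data shown here, the group on the amine nitrogen still matters when the methyl stays in place: furan-2-yl in place of 3-methylbut-2-en-1-yl gives a 3.7-fold higher number from compound 2 to compound 4 (0.57 log units; beyond the scatter) on this read-out, and this is the first sign that the replacing group sets the size of the drop. No measurement shown here explains why these groups differ.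

The compounds shown do not separate the role of the furan ring from that of its size, and a benzyl group or a tetrahydrofuran-2-ylmethyl group in its place would address that. They also leave open what the methyl on the amine nitrogen contributes, which the secondary (furan-2-yl)methylamino group on the same ring carbon would test.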